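Piperidine Ring in Place of Dimethylamino: Cytotoxicity Outlook

The compounds below may be only part of what the source reports. "The series", "measured", "known", "first", "only" and "open" are said of these compounds alone.

Three measured compounds share one core and differ in the amine group on the aromatic ring and in the amide side chain. Compound 1 `NC(=O)C1CCN(c2cc3c(cc2F)c(=O)c(C(=O)NCc2ccco2)cn3C2CC2)CC1` carries a carboxamide-bearing piperidine and a furan-containing amide. In an ADME assay on J774.1 cells (Mus musculus) for cytotoxicity, read by resazurin assay, with a stated time of 48 h (on this read-out lower numbers stand for stronger inhibition and higher numbers for weaker inhibition), compound 1 gives > 100000 nM, which is a limit of the assay rather than a number. Compound 2 `CCCCn1cc(C(=O)NCc2ccc(OC)cc2)c(=O)c2cc(F)c(N3CCC(C(N)=O)CC3)cc21`, with a methoxy-substituted benzyl amide, gives 40800 nM in this assay. Compound 3 `CCCCn1cc(C(=O)NCc2ccccc2)c(=O)c2cc(F)c(N(C)C)cc21`, with a plain benzyl amide and a dimethylamino group, gives > 100000 nM in this assay; this again is a limit and not a measured number. Compound 3 therefore stands where two of the three results sit, at the limit of > 100000 nM in this assay, at which 2 of the 3 values shown sit, and only compound 2 returns a number.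

Compound 4 `CCCCn1cc(C(=O)NCc2ccccc2)c(=O)c2cc(F)c(N3CCCCC3)cc21` differs from compound 3 in one place: piperidin-1-yl in place of dimethylamino on an aromatic carbon. Within the data shown here, no step between two measured compounds is available to guide the size of the change. The expectation is a step of an at least 1.2-fold lower number from compound 3 to compound 4 (0.09 log units; that floor lies within the scatter) that stays within the usual scatter, or at most a modest move toward stronger inhibition. Compound 4 is thus expected to give about 80000 nM in this assay, with the estimate ranging from 30000 nM to 200000 nM.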

Compound 4, half-maximal inhibitory concentration: 47800 nM
Compound 4: middle estimate off by 1.7-fold (0.22 log units), on the high side, within the range that was stated.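

In this assay, replacing dimethylamino with piperidin-1-yl on this aromatic carbon gives an at least 2.0-fold lower number from compound 3 to compound 4 (0.32 log units; beyond the scatter). Compound 3 sits at a limit of the assay and not at a measured number, so this step gives only the smallest possible size of the change: the limit of > 100000 nM in this assay, at which 2 of the 4 values shown sit. Among these compounds, it is also the first comparison here in which only one place differs, and it shows that the group on this carbon, ortho to a fluoro group, can by itself shift the cytotoxicity read-out, which the earlier compounds could not show because they differ in more than one place.

The compounds shown leave open whether the ring itself matters or only the larger group, a question that diethylamino, an open-chain group, could help settle when set against the piperidin-1-yl ring at the same carbon. They also leave open how a ring with a second hetero atom, such as morpholin-4-yl or piperazin-1-yl, would read at this place while the rest of compound 4 stays the same.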